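The compounds below may be only part of what the source reports. "The series", "measured", "known", "first", "only" and "open" are said of these compounds alone.

In a toxicity assay on HepG2 2.2.15 cells (Homo sapiens) for cytotoxicity, read by CCK-8 assay, with a stated time of 8 days (a higher number here means that more compound is tolerated, a lower number that less compound is tolerated), three compounds have been tested so far. Compound 1 `CCOC(=O)c1cn(-c2nccs2)nc1CC(C)C` gives only a limit of the assay, > 100000 nM. Compound 2 `CC(C)Cc1nn(-c2cccc(F)c2)cc1C(=O)NCC1CCN(C(=O)OC(C)(C)C)CC1` also gives only a limit, > 100000 nM. Compound 3 `CC(C)Cc1nn(-c2nccs2)cc1C(=O)NCc1cccc(F)c1` likewise gives only a limit, > 100000 nM. All three values sit at the same limit, as the limit of > 100000 nM in this assay, at which 3 of the 3 values shown sit, records, so nothing separates compound 3 from the other two. Compound 4 `CC(C)Cc1nn(-c2nccs2)cc1C(=O)Nc1ccc(F)cc1` is not yet measured; it differs from compound 3 by 4-fluorophenyl in place of 3-fluorobenzyl on an amide-type nitrogen. For the measured compounds named here, no measured pair differs in a single place, so no step size can be read from the data. The step from compound 3 to compound 4 in this assay is expected to be a number no higher from compound 3 to compound 4 (the limit leaves the size open), nothing beyond the usual scatter. Compound 4 is therefore estimated at 100000 nM, within 60000 nM to 200000 nM.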

Compound 4, half-maximal cytotoxic concentration: 83700 nM
Estimate against measurement, compound 4: 1.2-fold (0.08 log units) above, within the range that was stated.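

In this assay, for the compounds shown here, compound 4 is the first to give an actual number, 83700 nM. From the compounds shown here alone, the other values are limits, not numbers: the limit of > 100000 nM in this assay, at which 3 of the 4 values shown sit. Placing 4-fluorophenyl instead of 3-fluorobenzyl on the amide-type nitrogen gives an at least 1.1-fold lower number from compound 3 to compound 4 (0.07 log units; that floor lies within the scatter), and placing (4-fluorophenyl)amino instead of ethoxy on the carbonyl carbon gives an at least 1.1-fold lower number from compound 1 to compound 4 (0.07 log units; that floor lies within the scatter); the true size of each step stays open, as each starts from a limit.

Going by these compounds, whether an amine, a carboxylic acid or a longer chain on that nitrogen would move the number beyond the scatter remains open.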